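The source may report more compounds than this note shows. Statements on the series, on what has been measured and on what is new or still open speak of the compounds shown alone.

Working notes on the series. Among the compounds with values here, compound 3 `O=c1cc(-n2cc(COc3ccc(F)cc3)nn2)c2cc(Br)ccc2o1` gives 850 nM in a functional assay on A549 cells (Homo sapiens) for antiproliferative activity, read by MTT assay, with a stated time of 48 h (a higher number here means a weaker inhibitor, a lower number a stronger inhibitor), the lowest of the three numbers measured so far. Compound 2 `O=c1cc(-n2cc(COc3ccc(C(F)(F)F)cc3)nn2)c2cc(Br)ccc2o1` gives 1620 nM in this assay, and compound 1 `Nc1ccc(OCc2cn(-c3cc(=O)oc4ccc(Br)cc34)nn2)cc1` gives 11900 nM. All three differ only in the group on the phenoxy ring, so the steps between them bear directly on any further swap at that position: a 7.3-fold lower number from compound 1 to compound 2 (0.87 log units; beyond the scatter) and a 14-fold lower number from compound 1 to compound 3 (1.15 log units; beyond the scatter) both lie beyond the scatter, while a 1.9-fold lower number from compound 2 to compound 3 (0.28 log units; within the scatter) stays within it. Compound 4 `COC(=O)c1ccc(OCc2cn(-c3cc(=O)oc4ccc(Br)cc34)nn2)cc1` differs from compound 3 in one place: methoxycarbonyl in place of fluoro on an aromatic carbon. Within the data shown here, no measured step carries this group, so the expectation rests only on how far the three swaps at this position moved the number: at most the largest step, with two of the three groups standing close together. For compound 4 the estimate in this assay is 1600 nM, between 500 nM and 6000 nM. This implies an expected step of a 1.9-fold higher number from compound 3 to compound 4 (0.27 log units; within the scatter), a modest weakening whose range leaves either direction open.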

Compound 4, half-maximal inhibitory concentration: 660 nM
Estimate against measurement, compound 4: 2.4-fold (0.38 log units) above, within the range that was stated.
By their numbers in this assay, from the lowest: compounds 4, 3 and 2 (each within the scatter of the next, the first and the last beyond it); then compound 1.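

In this assay, within the data shown here, a 1.3-fold lower number from compound 3 to compound 4 (0.11 log units; within the scatter) stays within the scatter, so methoxycarbonyl, the larger group and one with hydrogen-bond acceptors, cannot be told apart from fluoro at this position. a 2.5-fold lower number from compound 2 to compound 4 (0.39 log units; beyond the scatter) lies beyond the scatter and is the first such step among the groups other than amino, although it is only modest and compound 2 stays within the scatter of compound 3. an 18-fold lower number from compound 1 to compound 4 (1.26 log units; beyond the scatter) is large, which extends the earlier picture: amino remains set well apart from all three other groups at this position.

From the compounds shown here alone, whether a carboxylic acid or a primary amide here would read with compound 4 or move towards compound 1 stays open, as does the reading for a longer ester chain. Nothing at hand accounts for the separate standing of amino in this series.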